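The source may report more compounds than this note shows. Statements on the series, on what has been measured and on what is new or still open speak of the compounds shown alone.

For the measured compounds named here, in a functional assay on the whole organism for inhibition, with Rattus norvegicus as the target (a lower number here means that less compound is needed, a higher number that more compound is needed for the effect), compound 3 `COC(=O)c1cccnc1N1CCN(CCCCN2C(=O)SC3(CCCC3)C2=O)CC1` gives 50.2 mg/kg as its dose, the only actual number in this small set. Compound 1 `Cc1cccnc1N1CCN(CCCCN2C(=O)SC3(CCCC3)C2=O)CC1` is reported only as a limit (> 50 mg/kg). Compound 2 `COc1cccnc1N1CCN(CCCCN2C(=O)SC3(CCCC3)C2=O)CC1` is likewise reported only as a limit (< 57 mg/kg). Compound 4 `N#Cc1cccnc1N1CCN(CCCCN2C(=O)SC3(CCCC3)C2=O)CC1` keeps the core of compound 3 and differs in one group: cyano in place of methoxycarbonyl on an aromatic carbon. In words, this is cyano in place of methoxycarbonyl on an aromatic carbon. The measured steps at this same place are a step that the limit leaves unreadable from compound 1 to compound 3 and a step that the limit leaves unreadable from compound 2 to compound 3, together with a step that the limit leaves unreadable from compound 1 to compound 2. None of them has a readable size, so they offer no scale and no direction for the new change. That leaves compound 3 at 50.2 mg/kg as the only anchor. The expected result in this assay is a 1.0-fold lower number from compound 3 to compound 4 (0.00 log units; within the scatter) and no shift beyond the scatter in either direction. The estimate for compound 4 is 50 mg/kg with an expected range from 22 mg/kg to 110 mg/kg as its span.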

Compound 4, dose for half-maximal effect: 29.3 mg/kg
Compound 4: the middle estimate sits 1.7-fold (0.23 log units) above what was measured, within the range that was stated.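

In this assay, for the compounds shown here, the change from 3-(methoxycarbonyl)pyridin-2-yl to 3-cyanopyridin-2-yl gives the first step of readable size at this position: there is a 1.7-fold lower number from compound 3 to compound 4 (0.23 log units; within the scatter), so replacing the methoxycarbonyl with cyano does not move the dose beyond the scatter. Against the methyl group of compound 1 the data give only a floor, and that floor also stays within the scatter: there is an at least 1.7-fold lower number from compound 1 to compound 4 (0.23 log units; that floor lies within the scatter). The step between compound 2 and compound 4 cannot be read, because compound 2 is reported only as a limit: the limit of < 57 mg/kg in this assay, at which 1 of the 4 values shown sits.

Going by these compounds, whether any group at this position can carry the dose beyond the scatter remains open. On these data alone, what a carboxylic acid, an amine or a chlorine atom would do in place of the cyano also stays unknown from these compounds.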